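Halogenated phenyl hydrazones in a cytotoxicity series

The source may hold more compounds than are shown below. What is called first, only, known or untested is meant among the compounds shown, and "the series" means these compounds.

The shared core of compound 3 `CN(C)CCn1cnnc1-c1cc(Oc2ccc(NC(=O)N/N=C/c3cccc(Cl)c3Cl)cc2F)ccn1` carries a 2,3-dichlorophenyl group on the carbon with a double bond to nitrogen, and in a functional assay on NCI-H460 cells (Homo sapiens) for cytotoxicity, read by MTT assay, with a stated time of 72 h (a higher number here means a weaker inhibitor, a lower number a stronger inhibitor), compound 3 gives 72 nM, the lowest number among the three measured compounds. Compound 1 `CN(C)CCn1cnnc1-c1cc(Oc2ccc(NC(=O)N/N=C/c3c[nH]c4ccccc34)cc2F)ccn1` gives 1630 nM in this assay, and compound 2 `CN(C)CCn1cnnc1-c1cc(Oc2ccc(NC(=O)N/N=C/c3ccc(F)cc3F)cc2F)ccn1` gives 1930 nM; the step of a 1.2-fold higher number from compound 1 to compound 2 (0.07 log units; within the scatter) lies within the scatter. Against these, the steps of a 23-fold lower number from compound 1 to compound 3 (1.35 log units; beyond the scatter) and a 27-fold lower number from compound 2 to compound 3 (1.43 log units; beyond the scatter) are both large, so the dichlorophenyl group sets compound 3 clearly apart. Compound 4 `CN(C)CCn1cnnc1-c1cc(Oc2ccc(NC(=O)N/N=C/c3cccc(Br)c3)cc2F)ccn1` differs from compound 3 by the change (3-bromophenyl in place of 2,3-dichlorophenyl on a carbon with a double bond to nitrogen). For the measured compounds named here, no measured step bears directly on exchanging one halogenated phenyl for another of this kind; the step from compound 2 to compound 3 shows that a halogenated phenyl can give either a high or a low number. Compound 4 is therefore expected to fall between them, with a step of a 3.5-fold higher number from compound 3 to compound 4 (0.54 log units; beyond the scatter) that is estimated to be modest. In this assay compound 4 is expected to give about 250 nM, within a range of 70 nM to 1200 nM.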

Compound 4, half-maximal inhibitory concentration: 520 nM
Estimate against measurement, compound 4: 2.1-fold (0.32 log units) below; low and high end bracket the measured number.
By their numbers in this assay, from the lowest: compound 3; then compound 4; then compounds 1 and 2 (each within the scatter of the next).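

In this assay the 3-bromophenyl group fills the gap between the low number of compound 3 and the high numbers of compounds 1 and 2, so this position does not give only two levels of result. The step of a 7.2-fold higher number from compound 3 to compound 4 (0.86 log units; beyond the scatter) and the step of a 3.7-fold lower number from compound 2 to compound 4 (0.57 log units; beyond the scatter) run in opposite directions, which shows that halogenated phenyl groups on this carbon spread over three distinct levels. The step of a 3.1-fold lower number from compound 1 to compound 4 (0.50 log units; beyond the scatter) shows that compound 4 also stands clearly apart from the compound carrying 1H-indol-3-yl.

On these data alone, this change alters both the halogen and the number of halogens, so the two cannot be separated here, and what a phenyl bearing a methoxy group or a carboxylic acid would give remains open. Nothing shown here accounts for the differences among these groups.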